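Aryl ether swap on a thromboxane synthase inhibitor

The source may report more compounds than this note shows. Statements on the series, on what has been measured and on what is new or still open speak of the compounds shown alone.

Three compounds sharing one core differ only in the aryl group on the ether oxygen. Compound 1 `Cc1ccc(C#N)c(OC(C)(C)C2OCC(C/C=C\CCC(=O)O)C(c3cccnc3)O2)c1` gives 50 nM in an assay for inhibition of Thromboxane-A synthase (Homo sapiens), using microsomes (a higher number here means a weaker inhibitor, a lower number a stronger inhibitor), compound 2 `COc1ccc(OC(C)(C)C2OCC(C/C=C\CCC(=O)O)C(c3cccnc3)O2)cc1` gives 41 nM, and compound 3 `CC(C)(Oc1ccccc1Br)C1OCC(C/C=C\CCC(=O)O)C(c2cccnc2)O1` gives 29 nM, the lowest of the three numbers, though its gaps to compounds 1 and 2 lie within the scatter. Compound 4 `COc1ccc(OC(C)(C)C2OCC(C/C=C\CCC(=O)O)C(c3cccnc3)O2)c([N+](=O)[O-])c1` carries 4-methoxy-2-nitrophenyl in place of 2-bromophenyl on an oxygen on a saturated carbon. Among the compounds with values here, the steps that bear on this change are a 1.4-fold lower number from compound 2 to compound 3 (0.15 log units; within the scatter) and a 1.7-fold lower number from compound 1 to compound 3 (0.24 log units; within the scatter), both within the scatter, so swapping one aryl group for another has so far moved nothing beyond noise. For compound 4 the step of a 1.4-fold higher number from compound 3 to compound 4 (0.14 log units; within the scatter) is therefore expected to stay within the scatter. Compound 4 is estimated at 40 nM, with a range from 15 nM to 110 nM.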

Compound 4, half-maximal inhibitory concentration: 37 nM
Compound 4: middle estimate off by 1.1-fold (0.03 log units), on the high side, and the stated range covers the measured number.
By their numbers in this assay, from the lowest: compounds 3, 4, 2 and 1 (each within the scatter of the next).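

Nitro in place of hydrogen on an aromatic carbon is the one clean single-group change here, and in this assay it stays within the scatter (a 1.1-fold lower number from compound 2 to compound 4 (0.04 log units; within the scatter)). The two whole-group swaps also stay within it (a 1.3-fold higher number from compound 3 to compound 4 (0.11 log units; within the scatter)) and (a 1.4-fold lower number from compound 1 to compound 4 (0.13 log units; within the scatter)), even though 4-methoxy-2-nitrophenyl counts 3 hydrogen-bond acceptors where 2-bromophenyl counts 0. All four aryl groups therefore read alike at this position. From the compounds shown here alone, whether an aryl group bearing an amine, or a plain alkyl chain in place of the aryl group, would read the same remains open. No measurement at hand gives a reason for this flat picture.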